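Carbamate in place of prenyl ether at the ring oxygen

The source may report more compounds than this note shows. Statements on the series, on what has been measured and on what is new or still open speak of the compounds shown alone.

Measured compounds:
compound 1, `CC(C)=CCOc1cc(=O)n(CCCO)c2c1CC(CC=C(C)C)C(C)(C)C2`: 20.7%
compound 2, `CC(C)=CCC1Cc2c(OCCCNC(=O)c3ccco3)cc(=O)n(CCCO)c2CC1(C)C`: 2.1%
compound 3, `CC(C)=CCC/C(C)=C/CC1Cc2c(OCC=C(C)C)cc(=O)n(CCCO)c2CC1(C)C`: 30.3%

In a functional assay on PANC-1 cells (Homo sapiens) for inhibition, read by MTT assay, with a stated time of 24 h, tested at 10 uM (a higher number here means more inhibition at the concentration tested (going by the name of the read-out), a lower number less inhibition), compound 3 gives 30.3%, the highest of the three numbers. Compound 1 gives 20.7%, a gap within the scatter, so no order between compound 3 and compound 1 can be claimed. Compound 2 gives 2.1%, a gap beyond the scatter.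

Compound 4, `CC(C)=CCC/C(C)=C/CC1Cc2c(OC(=O)Nc3ccc(F)cc3)cc(=O)n(CCCO)c2CC1(C)C`, is not yet measured in this assay. It differs from compound 3 by (4-fluorophenyl)carbamoyl in place of 3-methylbut-2-en-1-yl on an oxygen on an aromatic ring. Among the measured compounds shown here, one measured step bears on this: a number 18.6 percentage points lower from compound 1 to compound 2 (beyond the scatter), where a hydrocarbon alkenyl group attached through the oxygen on the aromatic ring likewise gave way to a group carrying a carbonyl and an amide hydrogen. The other step, a number 9.6 percentage points higher from compound 1 to compound 3 (within the scatter), concerns a different place and offers no guidance here. For the measured compounds named here, the single comparable step points to a drop beyond the scatter, and the same direction is expected for this change: a number 16.3 percentage points lower from compound 3 to compound 4 (beyond the scatter). Compound 4 is therefore estimated at 14%, with a range from 0% to 30%.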

Compound 4, a percentage reported as inhibition, at one concentration (the size of the read-out at that concentration, not a potency): 43.9%
For compound 4 the middle estimate is 29.9 percentage points below the measured one; the measured number lies above the stated range.
By their numbers in this assay, from the lowest: compound 2; then compounds 1 and 3 (each within the scatter of the next); then compound 4.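

In this assay, the oxygen on an aromatic ring accepts more than a hydrocarbon group: (4-fluorophenyl)carbamoyl in place of 3-methylbut-2-en-1-yl gives a gain (a number 13.6 percentage points higher from compound 3 to compound 4 (beyond the scatter)). Change at this oxygen therefore has no single direction, as the other listed replacement there went the opposite way (a number 18.6 percentage points lower from compound 1 to compound 2 (beyond the scatter)), so a carbonyl and an amide hydrogen in the entering group do not alone settle the outcome. No available measurement explains why the two replacements diverge.

As far as these compounds go, whether the gain needs the fluorine, the aromatic ring or the carbamoyl link stays open; an unsubstituted phenylcarbamoyl, a 4-chlorophenylcarbamoyl or a benzoyl group at the same oxygen would separate these. Also open, from the compounds shown here alone, is whether (4-fluorophenyl)carbamoyl acts alike on the core of compound 1, which carries the shorter chain.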